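Cyano to methyl on the aryl ring: pyridyl case

This account rests on a few compounds, and the source may have more. Where it says the series, first, only, none or still open, it means among the compounds named here.

Compound 1 `Cc1cccc(/C(CCN2CCN(c3ccccn3)CC2)=N/O)c1` gives 2.3 nM in a functional assay on HEK293 cells with D(4) dopamine receptor (Homo sapiens) as the target, read by FLIPR; on this read-out lower numbers stand for an effect already at smaller amounts and higher numbers for an effect only at larger amounts of compound. Compound 2 `N#Cc1cccc(/C(CCN2CCN(c3ccccn3)CC2)=N/O)c1` gives 13.1 nM in this assay. The change methyl in place of cyano on an aromatic carbon produced a 5.7-fold lower number from compound 2 to compound 1 (0.76 log units; beyond the scatter). Compound 3 `CCO/N=C(\CCN1CCN(c2ncccc2C#N)CC1)c1ccccc1` gives 139 nM in this assay, the highest of the three numbers; how its core differs from that of compound 2 is not broken down here. Compound 4 `CCO/N=C(\CCN1CCN(c2ncccc2C)CC1)c1ccccc1` is still to be measured in this assay. It differs from compound 3 by methyl in place of cyano on an aromatic carbon, the same kind of change as from compound 2 to compound 1, though here the place is on a six-membered aromatic ring with one nitrogen, ortho to a large group and two atoms from the ring nitrogen, rather than on a ring of carbon only, meta to a large group. Compound 4 is expected to show a step of a 4.0-fold lower number from compound 3 to compound 4 (0.60 log units; beyond the scatter), resting on a 5.7-fold lower number from compound 2 to compound 1 (0.76 log units; beyond the scatter); the range is set wide, as a single prior example is all that exists. For compound 4 the estimated value in this assay is 35 nM, between 10 nM and 140 nM.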

Compound 4, half-maximal effective concentration: 253 nM
Estimate against measurement, compound 4: 7.2-fold (0.86 log units) below; the measured number lies above the stated range.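

In this assay methyl in place of cyano on the six-membered aromatic ring with 1 nitrogen gives a 1.8-fold higher number from compound 3 to compound 4 (0.26 log units; within the scatter). The step seen on the core of compound 1 therefore does not carry over in size to the core of compound 4: the same change on two cores in this assay, a 5.7-fold lower number (0.76 log units; beyond the scatter) from compound 2 to compound 1 and a 1.8-fold higher number (0.26 log units; within the scatter) from compound 3 to compound 4, 10-fold (1.02 log units) apart, beyond the scatter of two such steps. This shows that the outcome of the change depends on its setting in these two pairs, but the pairs differ in more than one feature, so they do not show which difference matters, and two pairs give no rule for the series.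

Going by these compounds, it remains open how a chlorine atom or a methoxy group would behave in the same place. Also open, on these data alone, is whether methyl in place of cyano on the carbon-only ring gives a similar step with an ethyl group on the oxime oxygen.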